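The compounds below may be only part of what the source reports. "The series", "measured", "known", "first", "only" and "open" are said of these compounds alone.

Of the compounds shown here, two have been measured in a functional assay on SR cells (Homo sapiens) for inhibition, read by sulforhodamine B assay, with a stated time of 48 h, tested at 10 uM; on this read-out lower numbers stand for less inhibition and higher numbers for more inhibition at the one concentration tested (going by the name of the read-out). Compound 1 `Brc1cn2ccnc2c(-c2ccc3ncn(C4CCCCC4)c3c2)n1` carries a single cyclohexyl-bearing bicyclic arm on its core, and in this assay compound 1 gives 26.8%. Compound 2 `c1cn2cc(-c3ccc4c(c3)ncn4C3CCCCC3)nc(-c3ccc4ncn(C5CCCCC5)c4c3)c2n1` carries two such arms, and in this assay compound 2 gives 50%. Compound 2 therefore stands highest of the two numbers recorded; its nearest neighbour is compound 1, whose number lies below it by a gap that is beyond the usual scatter of repeated measurements.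

The step under consideration leads from compound 2 to compound 3 `c1ccc(Cn2cnc3ccc(-c4nc(-c5ccc6c(c5)ncn6C5CCCCC5)cn5ccnc45)cc32)cc1`, in which (benzyl in place of cyclohexyl on an aromatic nitrogen). The change sits on an aromatic nitrogen of a five-membered aromatic ring with 2 nitrogen, part of a fused or bridged system of two rings, while the second cyclohexyl-bearing arm of compound 2 is kept. Among the measured compounds shown here, no measured pair in this set shows the effect of such an exchange, so any expectation rests on compound 2 alone. The step from compound 2 to compound 3 is expected to be small, if any, and within the scatter, amounting to a number 5 percentage points lower from compound 2 to compound 3 (within the scatter). Compound 3 is accordingly estimated to give 45% in this assay, with a plausible range from 20% to 70%.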

Compound 3, a percentage reported as inhibition, at one concentration (the size of the read-out at that concentration, not a potency): 94.6%
Estimate against measurement, compound 3: 49.6 percentage points below; measured number outside the range, above it.
By their numbers in this assay, from the lowest: compound 1; then compound 2; then compound 3.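

Exchanging cyclohexyl for benzyl on this aromatic nitrogen gives a number 44.6 percentage points higher from compound 2 to compound 3 (beyond the scatter) in this assay and so shows that the group held at this position can change the read-out strongly, even with the second cyclohexyl-bearing arm left as it is. By the counts, the exchange replaces a six-membered non-aromatic ring of carbon only with a six-membered aromatic ring of carbon only and adds one carbon, with no hydrogen-bond donor or acceptor on either side, so a change confined to carbon atoms is enough for a step of this size. No measurement here explains why the step is so large.

The compounds shown leave open whether the gain follows from the aromatic ring itself or from the ring being held on one carbon, which a phenyl group directly on the nitrogen or a longer phenethyl chain would help to separate. They also leave open whether the number would be higher, lower or level with other groups at this position, such as a benzyl ring bearing an amine or a carboxylic acid, and whether the same exchange on the second arm would give a further step.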